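Half-life notes on a three-compound series

A few compounds are considered here, and "the series" means these few. Any claim that something is new, unique, unknown or untested is made for them only; others in the source may bear on it.

Measured in an ADME assay on microsomes from liver (Homo sapiens) for metabolic stability, read by LC-MS, using NADPH, tested at 5 uM; on this read-out higher numbers stand for a longer-lived compound and lower numbers for a shorter-lived compound:
compound 1 `Cc1cc(S(=O)(=O)/N=C(\N)N/N=C/C#Cc2ccccc2)c(SCc2ccccc2)cc1Cl` gives 0.469 h;
compound 2 `Cc1cccc(CSc2cc(Cl)c(C)cc2S(=O)(=O)/N=C(\N)N/N=C/C#Cc2ccccc2)c1` gives 0.879 h;
compound 3 `Cc1cc(S(=O)(=O)/N=C(\N)N/N=C/C#Cc2ccccc2)c(SCc2ccccc2Cl)cc1Cl` gives 0.254 h.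

Compound 3 holds the lowest of the three numbers; its gap to compound 1 is within the scatter, while the step of a 3.5-fold lower number from compound 2 to compound 3 (0.54 log units; beyond the scatter) lies beyond it. Compound 4 `Cc1cc(S(=O)(=O)/N=C(\N)N/N=C/C#Cc2ccccc2)c(SCc2ccc(Cl)cc2)cc1Cl` differs from compound 3 by 4-chlorophenyl in place of 2-chlorophenyl on a saturated chain carbon bound to a sulfur. Among the compounds with values here, no measured step relocates the chloro within the benzyl group. Within the data shown here, the one step at the same place, a 3.5-fold lower number from compound 2 to compound 3 (0.54 log units; beyond the scatter), exchanges two unlike groups, and the steps of a 1.9-fold higher number from compound 1 to compound 2 (0.27 log units; within the scatter) and a 1.8-fold lower number from compound 1 to compound 3 (0.27 log units; within the scatter) both stay within the scatter. The change is therefore expected to move this assay little, with an estimated step of a 1.4-fold higher number from compound 3 to compound 4 (0.14 log units; within the scatter) that stays within the scatter. For compound 4 the expected value is 0.35 h, with a range from 0.15 h to 0.8 h.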

Compound 4, half-life: 0.665 h
Estimate against measurement, compound 4: 1.9-fold (0.28 log units) below; low and high end bracket the measured number.
By their numbers in this assay, from the lowest: compounds 3, 1, 4 and 2 (each within the scatter of the next, the first and the last beyond it).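

Relocating the chloro within the benzyl group does register in this assay: a 2.6-fold higher number from compound 3 to compound 4 (0.42 log units; beyond the scatter), so 2-chlorobenzyl and 4-chlorobenzyl are not interchangeable at this place. The 4-chlorobenzyl group stays close to both the benzyl and 3-methylbenzyl groups, with a 1.4-fold higher number from compound 1 to compound 4 (0.15 log units; within the scatter) and a 1.3-fold lower number from compound 2 to compound 4 (0.12 log units; within the scatter). Nothing available here bears on the reason for the step between the two chlorobenzyl groups.

On these data alone, whether this sensitivity to chloro placement extends to other substituents stays open. A methoxy group or a carboxylic acid in place of the chloro would have to show that.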